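A few compounds are considered here, and "the series" means these few. Any claim that something is new, unique, unknown or untested is made for them only; others in the source may bear on it.

Of the compounds shown here, three share one core and have been tested in a functional assay for agonist activity at Bile acid receptor (Homo sapiens), read by FRET; on this read-out higher numbers stand for an effect only at larger amounts of compound and lower numbers for an effect already at smaller amounts. Compound 1 `CC(C)c1onc(-c2c(Cl)cccc2Cl)c1COc1ccc(-c2ccc3c(C(=O)O)nccc3c2)cc1` carries an acid on its core and gives 380 nM. Compound 2 `CC(C)c1onc(-c2c(Cl)cccc2Cl)c1COc1ccc(-c2ccc3nc(C(=O)O)cc(O)c3c2)cc1` adds a hydroxyl to a rearranged core and gives 51 nM. Compound 3 `COc1cc(C(=O)O)nc2ccc(-c3ccc(OCc4c(-c5c(Cl)cccc5Cl)noc4C(C)C)cc3)cc12` has a methyl on that oxygen and gives 58 nM. The step of a 1.1-fold higher number from compound 2 to compound 3 (0.06 log units; within the scatter) shows that capping the oxygen with a methyl left the number essentially where it was. On the numbers shown, compound 3 sits close to compound 2, with a gap inside the scatter, while the number of compound 1 lies well above both, beyond the scatter.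

Compound 4 `CC(C)Oc1cc(C(=O)O)nc2ccc(-c3ccc(OCc4c(-c5c(Cl)cccc5Cl)noc4C(C)C)cc3)cc12` has not yet been measured. It differs from compound 3 by isopropyl in place of methyl on an oxygen on an aromatic ring. Among the measured compounds shown here, the only measured step that touches this oxygen is the one from hydrogen to methyl, which was within the scatter, so there is no sign yet that the size of the group on this oxygen matters much. The expected step of a 1.2-fold higher number from compound 3 to compound 4 (0.08 log units; within the scatter) is therefore small, and no shift beyond the scatter is anticipated. Compound 4 is expected to give about 70 nM in this assay, with a likely range from 30 nM to 180 nM.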

Compound 4, half-maximal effective concentration: 40 nM
Compound 4: the middle estimate sits 1.8-fold (0.24 log units) above what was measured; measured number inside the range.
By their numbers in this assay, from the lowest: compounds 4, 2 and 3 (each within the scatter of the next); then compound 1.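

Compound 3 and compound 4 show the first test of a group bigger than methyl on this oxygen: methoxy gives way to isopropoxy, with 3 heavy atoms in the added group where methyl has 1, and this assay records a 1.5-fold lower number from compound 3 to compound 4 (0.16 log units; within the scatter). Measured against the free hydroxyl, the picture is the same, with a 1.3-fold lower number from compound 2 to compound 4 (0.11 log units; within the scatter), so hydrogen, methyl and isopropyl on this oxygen all give numbers that cannot be told apart on this read-out, and what was a single small step now holds over a wider span of group size. No supporting measurement is available that would explain why these numbers stay together.

As far as these compounds go, only these three small groups have been seen on this oxygen, so it remains open whether a longer chain, a phenyl ring or a chain ending in an amine would also stay within the scatter. The carboxylic acid is present in all the compounds shown, so they also say nothing about how a tetrazole in its place would read.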